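This account rests on a few compounds, and the source may have more. Where it says the series, first, only, none or still open, it means among the compounds named here.

compound 1 `c1ccc(COC[C@H]2OCC[C@@H](OCc3ccccc3)[C@@H]2OCc2ccccc2)cc1`: 39300 nM
compound 2 `C#CC[C@@H]1O[C@H](COCc2ccccc2)[C@@H](OCc2ccccc2)[C@H](OCc2ccccc2)[C@H]1O`: "not active" (no number reported)
compound 3 `CC(C)C[C@H]1O[C@H](COCc2ccccc2)[C@@H](OCc2ccccc2)[C@H](OCc2ccccc2)[C@@H]1O`: "not active" (no number reported)

These are the readings in a functional assay on HL-60 cells (Homo sapiens) for antiproliferative activity, read by MTT assay; a lower number here means a stronger inhibitor, a higher number a weaker inhibitor. Compound 2 has no single number to place it, and compound 3 is the one other entry without a number. Within the data shown here, only compound 1 gives a numerical reading, and no measured pair offers a step to lean on.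

Compound 4 `O[C@@H]1[C@@H](OCc2ccccc2)[C@H](OCc2ccccc2)[C@@H](COCc2ccccc2)O[C@H]1Cc1ccccc1` has not yet been measured in this assay. The structural change is phenyl in place of ethynyl on a saturated chain carbon bound to a saturated ring carbon, which can also be read as propargyl to benzyl.

The size of the step cannot be stated, since its starting point has no number. The expectation is a small move at most towards stronger inhibition, with a real chance that compound 4 also returns no number. Any reading is expected to lie near that of compound 1, at 39300 nM.

For compound 4 the estimated value is 40000 nM, with an expected range of 15000 nM to 100000 nM.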

Compound 4, half-maximal inhibitory concentration: 8700 nM
For compound 4 the middle estimate is 4.6-fold (0.66 log units) above the measured one; measured number outside the range, below it.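

Compound 2 has no number in this assay and the step from it to compound 4 cannot be read. The compounds shown leave open how far propargyl to benzyl alone moves the reading. Nothing shown offers an explanation for the reading of compound 4.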